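This account rests on a few compounds, and the source may have more. Where it says the series, first, only, none or still open, it means among the compounds named here.

Of the compounds shown here, three have been tested in a functional assay on RAW264.7 cells (Mus musculus) for inhibition, read by Griess assay, with a stated time of 20 h (on this read-out lower numbers stand for stronger inhibition and higher numbers for weaker inhibition), and none yet gives a number. Compound 1 (`CCCCCCc1cn(-c2ccc(C(=O)NCCC)c(O)c2)nn1`), which carries hexyl, reads > 20000 nM as a limit. Compound 2 (`O=C(c1ccc(-n2cc(-c3ccccc3)nn2)cc1O)N1CCCCC1`) reads > 20000 nM as a limit too. Compound 3 (`CC(C)CCc1cn(-c2ccc(C(=O)N3CCCCC3)c(O)c2)nn1`) reads > 20000 nM as a limit as well, so it stands with the other two, at the limit of > 20000 nM in this assay, at which 3 of the 3 values shown sit, and not on a true number. Within the data shown here, the only measured step, a step that the two limits leave unreadable from compound 2 to compound 3, offers no size to carry forward. Compound 4 (`CCCCCCc1cn(-c2ccc(C(=O)N3CCCCC3)c(O)c2)nn1`) differs from compound 3 by butyl in place of isopropyl on a saturated chain carbon, two bonds along the chain from an aromatic carbon and the same difference also reads isopentyl to hexyl. No step beyond the scatter is expected in this assay for this change, going by compound 1 at > 20000 nM as a limit. The expected change is a number no higher from compound 3 to compound 4 (the limit leaves the size open) as an estimate only. Compound 4 is estimated at 20000 nM with a range from 8000 nM to 40000 nM and is expected to read as a limit again.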

Compound 4, half-maximal inhibitory concentration: > 20000 nM
Compound 4: a limit, no number; the forecaster's own chance of this, stated with the estimate: 75%; the middle value sits exactly at the limit.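

In this assay compound 4 gives only a limit, as do compound 1, compound 2 and compound 3, so no step among these compounds can be read: the limit of > 20000 nM in this assay, at which 4 of the 4 values shown sit. From the compounds shown here alone, how strongly each of them inhibits, and whether any of the changes between them matters, stays open.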